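Compound 3: expected cytotoxicity after the ester change

The source may hold more compounds than are shown below. What is called first, only, known or untested is meant among the compounds shown, and "the series" means these compounds.

Among the measured compounds shown here, compound 1 `O=C(O)CCCC(=O)OCCc1c(-c2ccccc2Cl)c2cc(Cl)ccc2[nH]c1=O` gives 110000 nM in an ADME assay on HepG2 2.2.15 cells (Homo sapiens) for cytotoxicity (on this read-out lower numbers stand for higher toxicity in this test and higher numbers for lower toxicity in this test), the highest of the two numbers measured so far. Its nearest neighbour, compound 2 `O=C(OCCc1c(-c2ccccc2Cl)c2cc(Cl)ccc2[nH]c1=O)C1CCCC1`, gives 46000 nM in this assay; the step of a 2.4-fold lower number from compound 1 to compound 2 (0.38 log units; beyond the scatter) is modest but beyond the scatter, and the change behind it is cyclopentyl in place of 3-carboxypropyl on a carbonyl carbon.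

Compound 3 `COc1ccc(/C=C/C(=O)OCCc2c(-c3ccccc3Cl)c3cc(Cl)ccc3[nH]c2=O)cc1` has not yet been measured. It differs from compound 1 as follows: 2-(4-methoxyphenyl)ethenyl in place of 3-carboxypropyl on a carbonyl carbon. As in the step to compound 2, the 3-carboxypropyl group, with its one hydrogen-bond donor, gives way to a group with no donor; here the entering group is larger and brings a six-membered aromatic ring of carbon only. For the measured compounds named here, only the one measured step bears on the question, and it moved the number down. The expected move is in the same direction, at or somewhat beyond the size of a 2.4-fold lower number from compound 1 to compound 2 (0.38 log units; beyond the scatter). Going that way, the expected step is a 3.1-fold lower number from compound 1 to compound 3 (0.50 log units; beyond the scatter). Compound 3 is accordingly estimated at 35000 nM in this assay, within 15000 nM to 80000 nM; with a single neighbouring step as ground, the range is kept wide.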

Compound 3, half-maximal cytotoxic concentration: > 1200000 nM
Compound 3 gave a limit, no number (the forecaster's own chance of this, stated with the estimate: 10%); at least 34-fold (1.53 log units) between middle value and limit.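

Compound 3 is read only as a limit of the assay, not as a number: the limit of > 1200000 nM in this assay, at which 1 of the 3 values shown sits.

In this assay, this position on the carbonyl carbon proves able to carry far more than the modest shift seen earlier: the change to 2-(4-methoxyphenyl)ethenyl gives an at least 10-fold higher number from compound 1 to compound 3 (1.03 log units; beyond the scatter), and the change from cyclopentyl gives an at least 26-fold higher number from compound 2 to compound 3 (1.41 log units; beyond the scatter), both opposite in direction to a 2.4-fold lower number from compound 1 to compound 2 (0.38 log units; beyond the scatter). Removing the hydrogen-bond donor of the 3-carboxypropyl group therefore does not fix the direction of the step, since compound 2 and compound 3 both lack that donor yet fall on opposite sides of compound 1.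

The compounds shown do not separate the contributions of the six-membered aromatic ring, the double bond and the methoxy group within the entering group, a question that an unsubstituted phenylethenyl group or a saturated 2-(4-methoxyphenyl)ethyl chain at the same place would address. Also open, on these data alone, is whether an amine-bearing chain at this place would follow compound 1, compound 2 or compound 3, and the actual value of compound 3 remains undefined.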